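This account rests on a few compounds, and the source may have more. Where it says the series, first, only, none or still open, it means among the compounds named here.

Measured compounds:
- compound 1 `O=C(/C(=C\c1ccc2ccccc2n1)SCc1ccc(F)cc1)c1ccc(Br)cc1`, in a functional assay on DU-145 cells (Homo sapiens) for inhibition, read by trypan blue exclusion, with a stated time of 96 h (on this read-out lower numbers stand for stronger inhibition of growth and higher numbers for weaker inhibition of growth), compound 1 gives 25000 nM
- compound 2 `Cc1cc(F)ccc1/C=C(/SCc1ccc(F)cc1)C(=O)c1ccc(Br)cc1`, in this assay compound 2 gives 10000 nM
- compound 3 `O=C(/C(=C\c1ccc(O)cc1)SCc1ccc(F)cc1)c1ccc(Br)cc1`, in this assay compound 3 gives 10000 nM

Compound 3 stands level with compound 2, the two together the lowest numbers of the three; compound 1 sits further off, as a 2.5-fold lower number from compound 1 to compound 3 (0.40 log units; beyond the scatter) shows, with a 2.5-fold lower number from compound 1 to compound 2 (0.40 log units; beyond the scatter) of the same size.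

Compound 4 `O=C(/C(=C\c1ccc(Br)cc1)SCc1ccc(F)cc1)c1ccc(Br)cc1` differs from compound 3 by bromo in place of hydroxy on an aromatic carbon. For the measured compounds named here, the one step on the same aryl position, no change at the digits printed from compound 2 to compound 3 (within the scatter), was within the scatter, so a swap of the group on that ring has so far moved nothing in this assay. Going by the values given here, only one such step is known, so the expectation rests on little. A step of no size beyond the scatter, no change at the digits printed from compound 3 to compound 4 (within the scatter), is expected. Compound 4 is estimated at 10000 nM, within 4000 nM to 30000 nM.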

Compound 4, concentration for 50% growth inhibition: 25000 nM
Compound 4: the middle estimate sits 2.5-fold (0.40 log units) below what was measured; the range from low to high includes it.
By their numbers in this assay, from the lowest: compounds 2 and 3 (each within the scatter of the next); then compounds 1 and 4 (each within the scatter of the next).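

In this assay the group on this ring is no longer silent: bromo in place of hydroxy gives a step beyond the scatter (a 2.5-fold higher number from compound 3 to compound 4 (0.40 log units; beyond the scatter)), and 4-bromophenyl in place of 4-fluoro-2-methylphenyl gives another (a 2.5-fold higher number from compound 2 to compound 4 (0.40 log units; beyond the scatter)). A substituted phenyl here therefore does not by itself keep the lower number, since 4-bromophenyl stands with quinolin-2-yl (no change at the digits printed from compound 1 to compound 4 (within the scatter)). Nothing available explains the effect of this change. On these data alone, whether an amine, a carboxylic acid or chloro at this ring carbon would side with hydroxy or with bromo stays open.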